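Furan to thiazole on the amide carbonyl

The compounds below may be only part of what the source reports. "The series", "measured", "known", "first", "only" and "open" are said of these compounds alone.

In a functional assay on SF-268 cells (Homo sapiens) for inhibition, read by colorimetric assay and sulforhodamine B assay, with a stated time of 48 h (on this read-out higher numbers stand for weaker inhibition of growth and lower numbers for stronger inhibition of growth), compound 1 `CCCCCCCCCCCC[C@@H](O)[C@H]1CC[C@H]([C@H](O)CCCCCCCCCCNC(=O)c2ccco2)O1` gives 100000 nM. Compound 2 `CCCCCCCCCCCC[C@@H](O)[C@H]1CC[C@H]([C@H](O)CCCCCCCCCCNC(=O)c2ccoc2)O1` gives 100000 nM, level with compound 1. Compound 3 `CCCCCCCCCCCC[C@@H](O)[C@H]1CC[C@H]([C@H](O)CCCCCCCCCCNC(=O)c2cncs2)O1` has 1,3-thiazol-5-yl in place of furan-3-yl on a carbonyl carbon. Among the compounds with values here, one measured step bears on this change, a swap at the same carbonyl carbon: no change at the digits printed from compound 1 to compound 2 (within the scatter). On that single step, no change beyond the scatter is expected in this assay. The expected step is no change at the digits printed from compound 2 to compound 3 (within the scatter). The estimated value for compound 3 is 100000 nM, within a range of 40000 nM to 120000 nM.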

Compound 3, concentration for 50% growth inhibition: 100000 nM
Compound 3: middle estimate and measured number agree at the digits printed; the range from low to high includes it.
By their numbers in this assay, from the lowest: compounds 1, 2 and 3 (each within the scatter of the next).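

In this assay, 1,3-thiazol-5-yl in place of furan-3-yl on a carbonyl carbon gives no change at the digits printed from compound 2 to compound 3 (within the scatter) and 1,3-thiazol-5-yl in place of furan-2-yl gives no change at the digits printed from compound 1 to compound 3 (within the scatter) at the same place. The level read-out at this amide carbonyl therefore now extends beyond the two furans to a five-membered aromatic ring with 2 hetero atoms, one of them sulfur. Going by these compounds, whether a phenyl ring, an amine or a carboxylic acid at this place would move the read-out remains open. No evidence shown bears on why these three compounds stand level.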